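Working notes: amine replacement from compound 1 to compound 3

The compounds below may be only part of what the source reports. "The series", "measured", "known", "first", "only" and "open" are said of these compounds alone.

Measured so far:
compound 1 `COc1ccccc1Nc1cc(C)nc(SCc2nc3ccccc3[nH]2)n1` — 70800 nM
compound 2 `Cc1cc(Nc2cccc(C(F)(F)F)c2)nc(SCc2nc3ccccc3[nH]2)n1` — > 100000 nM

Going by the values given here, only two compounds have been run in a functional assay on PC-3 cells (Homo sapiens) for cytotoxicity, read by MTT assay, with a stated time of 72 h; on this read-out lower numbers stand for stronger inhibition and higher numbers for weaker inhibition. Compound 1 gives 70800 nM, a weak effect. For compound 2 the read-out is a limit of the assay rather than a number, > 100000 nM. Compound 1 therefore holds the only number shown, while the other entry sits at the limit of > 100000 nM in this assay, at which 1 of the 2 values shown sits.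

Compound 3 `Cc1cc(NCCO)nc(SCc2nc3ccccc3[nH]2)n1` differs from compound 1 in one place: 2-hydroxyethyl in place of 2-methoxyphenyl on a nitrogen on an aromatic ring. The shared core is untouched. Among the compounds with values here, no step between two measured compounds exists in this set, so the size of this change has no measured precedent.

The expected step of a 1.3-fold higher number from compound 1 to compound 3 (0.13 log units; within the scatter) is small, toward weaker inhibition, and probably within the usual scatter. Compound 3 is estimated at 95000 nM, with a range from 30000 nM to 300000 nM, and a fair chance that the assay reports only a limit.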

Compound 3, half-maximal inhibitory concentration: > 100000 nM
Compound 3: a limit, no number (the forecaster's own chance of this, stated with the estimate: 45%); middle value at least 1.0-fold (0.02 log units) away from the limit.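

In this assay, going by these compounds alone, 2-hydroxyethyl in place of 2-methoxyphenyl on a nitrogen on an aromatic ring gives the only step that can be read: an at least 1.4-fold higher number from compound 1 to compound 3 (0.14 log units; that floor lies within the scatter). Compound 3 gives > 100000 nM, which is a limit of the assay and not a number. The change therefore shows no gain from removing the aromatic ring at this place, and the read-outs now gather at one limit: the limit of > 100000 nM in this assay, at which 2 of the 3 values shown sit.

As far as these compounds go, the true size of the step stays open, since only its floor can be read. Also open, from the compounds shown here alone, is whether a 2-aminoethyl chain, a longer chain such as 3-hydroxypropyl, or a phenyl ring carrying a carboxylic acid on this nitrogen would read lower than compound 1.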